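The compounds below may be only part of what the source reports. "The series", "measured", "known", "first", "only" and "open" are said of these compounds alone.

Measured compounds and their values:

Compound 1, `Cc1ccc(S(=O)(=O)NC(=O)/C=C/c2ccc(F)cc2)cc1`: 4.8 ug/mL
Compound 2, `O=C(/C=C/c1ccc(F)cc1)NS(=O)(=O)c1ccc(F)cc1`: 0.8 ug/mL
Compound 3, `Cc1ccc(S(=O)(=O)NC(=O)/C=C/c2ccc(Br)cc2)cc1`: 12.1 ug/mL

All three were tested in a functional assay on B16-F10 cells (Mus musculus) for antiproliferative activity, read by ELISA and MTT assay, with a stated time of 48 h; a lower number here means a stronger inhibitor, a higher number a weaker inhibitor. Compound 4, `O=C(/C=C/c1ccc(Br)cc1)NS(=O)(=O)c1ccc(F)cc1`, has not yet been tested there.

The three measured compounds share a common framework and differ only in single substituents on the two outer rings. Compound 1 and compound 3 differ on the ring at the alkene end: bromo in place of fluoro on an aromatic carbon. That change gave a 2.5-fold higher number from compound 1 to compound 3 (0.40 log units; beyond the scatter), so compound 3 stands with the highest number of the three measured.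

Compound 1 and compound 2 differ on the other ring: fluoro in place of methyl on an aromatic carbon. That change gave a 6.0-fold lower number from compound 1 to compound 2 (0.78 log units; beyond the scatter), the largest step among these compounds.

Compound 4 is related to compound 3 in the same way: fluoro in place of methyl on an aromatic carbon. The place of the change is described in the same words in both pairs, so this is the same change, now made on the core of compound 3 rather than on the core of compound 1.

For the measured compounds named here, whether the step repeats at the same size cannot be known from one example, but it is the only guide available. A step of about a 4.8-fold lower number from compound 3 to compound 4 (0.68 log units; beyond the scatter) is expected for compound 4 because the same change gave a 6.0-fold lower number from compound 1 to compound 2 (0.78 log units; beyond the scatter). Compound 4 is therefore estimated at about 2.5 ug/mL in this assay. For compound 4 the expected range runs from 0.8 ug/mL to 8 ug/mL, allowing for the possibility that the step on this core is smaller or larger than the earlier one.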

Compound 4, half-maximal inhibitory concentration: 1.2 ug/mL
Compound 4: the middle estimate sits 2.1-fold (0.32 log units) above what was measured; the range from low to high includes it.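

In this assay, going from 4-methylphenyl to 4-fluorophenyl gave a 10-fold lower number from compound 3 to compound 4 (1.00 log units; beyond the scatter), so this change carried over from the core of compound 1 to the core of compound 3 in the same direction, and the two step sizes cannot be told apart: the same change on two cores in this assay, a 6.0-fold lower number (0.78 log units; beyond the scatter) from compound 1 to compound 2 and a 10-fold lower number (1.00 log units; beyond the scatter) from compound 3 to compound 4, 1.7-fold (0.23 log units) apart, within the scatter of two such steps

Bromo in place of fluoro on the other ring gave a 1.5-fold higher number from compound 2 to compound 4 (0.18 log units; within the scatter), a step too small to read as a real change on its own, and the two cases of this change also cannot be told apart: the same change on two cores in this assay, a 2.5-fold higher number (0.40 log units; beyond the scatter) from compound 1 to compound 3 and a 1.5-fold higher number (0.18 log units; within the scatter) from compound 2 to compound 4, 1.7-fold (0.23 log units) apart, within the scatter of two such steps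

Together, these four compounds show each change behaving alike on two cores, but each rests on only two examples, so this does not show that either step would carry over to a different core, and it gives no reason for the size of either step.

The outer rings shown carry only methyl, fluoro or bromo, so it remains open how a methoxy group, a nitrile or an amine would behave at the same place. Also open, on these data alone, is how much the shared core itself contributes, for example whether the number would hold if the alkene gave way to a saturated two-carbon chain.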